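The compounds below may be only part of what the source reports. "The series", "measured", "known", "first", "only" and "open" are said of these compounds alone.

In an ADME assay on MRC5 cells (Homo sapiens) for cytotoxicity, read by resazurin assay, with a stated time of 72 h (on this read-out higher numbers stand for weaker inhibition and lower numbers for stronger inhibition), two compounds sharing one core have been measured so far. Compound 1 (`O=[N+]([O-])c1cn2c(n1)OC(COc1ccc(-c3ccc(F)nc3F)cn1)CC2`) gives > 64000 nM, which is a limit of the assay and not a number. Compound 2 (`O=[N+]([O-])c1cn2c(n1)OC(COc1ccc(-c3ccc(F)cn3)cn1)CC2`) gives > 64000 nM, which is also a limit. Compound 2 therefore offers no number to start from, only (the limit of > 64000 nM in this assay, at which 2 of the 2 values shown sit). Within the data shown here, the single measured change bearing on the next one is a step that the two limits leave unreadable from compound 1 to compound 2, and its size cannot be read.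

Compound 3 (`O=[N+]([O-])c1cn2c(n1)OC(COc1ccc(-c3ccc(F)cc3F)cn1)CC2`) carries 2,4-difluorophenyl in place of 5-fluoropyridin-2-yl on an aromatic carbon, para to a large group: 2,4-difluorophenyl in place of 5-fluoropyridin-2-yl on an aromatic carbon. With no readable step as a guide, no change beyond the usual scatter is expected in this assay, and the result will most likely be another limit. The expected step is a number no higher from compound 2 to compound 3 (the limit leaves the size open). Compound 3 is estimated at 64000 nM, with an expected range from 30000 nM to 100000 nM.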

Compound 3, half-maximal inhibitory concentration: > 64000 nM
Compound 3: only a limit was reported; the forecaster's own chance of this, stated with the estimate: 80%; the middle value lies on the limit itself.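

In this assay compound 3 gives > 64000 nM, which is a limit and not a number. The steps linking compound 1, compound 2 and compound 3 therefore cannot be read. The compounds shown leave open whether these three differ at all in this assay.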